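The source may report more compounds than this note shows. Statements on the series, on what has been measured and on what is new or still open speak of the compounds shown alone.

Among the measured compounds shown here, in a physicochemical assay for lipophilicity, measured as octanol-water partition (on this read-out higher numbers stand for higher lipophilicity and lower numbers for lower lipophilicity), compound 2 `CCN1C(=O)c2c(nc(C(N)=O)n2Cc2ccc(O)c(Cl)c2)N2C1=N[C@@H]1CCC[C@@H]12` gives 2.76, the lower of the two values measured so far, while compound 1 `CCN1C(=O)c2c(nc(C(N)=O)n2Cc2ccc(OC)c(Br)c2)N2C1=N[C@@H]1CCC[C@@H]12` gives 3.3. Compound 3 `CCN1C(=O)c2c(nc(C(=O)NC)n2Cc2ccc(O)c(Cl)c2)N2C1=N[C@@H]1CCC[C@@H]12` differs from compound 2 by methyl in place of hydrogen on an amide-type nitrogen. For the measured compounds named here, the only measured step, a number 0.54 log units lower from compound 1 to compound 2 (beyond the scatter), concerns a different group, so no measured step bears directly on this change. A small rise, a number 0.24 log units higher from compound 2 to compound 3 (within the scatter), is expected, within or just beyond the usual scatter. Compound 3 is therefore estimated at 3, most likely falling between 2.6 and 3.4.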

Compound 3, partition coefficient: 3
The estimate for compound 3 equals the measured number at the digits printed, within the range that was stated.
By their numbers in this assay, from the lowest: compounds 2, 3 and 1 (each within the scatter of the next, the first and the last beyond it).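

In this assay, the first change shown at this amide-type nitrogen, methyl in place of hydrogen, gives a number 0.24 log units higher from compound 2 to compound 3 (within the scatter). Carbamoyl and methylcarbamoyl therefore cannot be told apart on this read-out, so a single methyl at this position does not produce a clear shift. Nothing measured here offers an explanation for this result.

From the compounds shown here alone, whether a longer chain such as propyl or a second methyl on this nitrogen would give a step beyond the scatter remains open. So does the effect of a carboxylic acid in place of the carbamoyl group.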